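Swapping 4-bromophenyl for 2-chlorophenyl: a small expected step

The source may report more compounds than this note shows. Statements on the series, on what has been measured and on what is new or still open speak of the compounds shown alone.

In a functional assay on MCF7 cells (Homo sapiens) for antiproliferative activity, read by MTT assay, with a stated time of 48 h (on this read-out lower numbers stand for stronger inhibition and higher numbers for weaker inhibition), compound 1 `COc1ccc(C2OC(c3ccc4ccccc4c3)=NN2C(C)=O)cc1` gives 7.35 ug/mL and compound 2 `CC(=O)N1N=C(c2ccc3ccccc3c2)OC1c1ccc(Br)cc1` gives 5.07 ug/mL. These two numbers lie within the usual scatter of each other, so compound 2 cannot be ranked against compound 1. Compound 3 `CC(=O)N1N=C(c2ccc3ccccc3c2)OC1c1ccccc1Cl` keeps the shared core and differs from compound 2 as follows: 2-chlorophenyl in place of 4-bromophenyl on a saturated ring carbon. In short, it has 2-chlorophenyl in place of 4-bromophenyl on a saturated ring carbon. For the measured compounds named here, only one measured step offers guidance, a 1.4-fold lower number from compound 1 to compound 2 (0.16 log units; within the scatter), with bromo in place of methoxy on an aromatic carbon, and it stays within the scatter. Going by the values given here, no measured compound carries 2-chlorophenyl, so the data favour no direction. The expected change is a 1.2-fold higher number from compound 2 to compound 3 (0.07 log units; within the scatter), no step beyond the scatter. In this assay compound 3 is estimated at 6 ug/mL, with an expected range from 2.5 ug/mL to 14 ug/mL.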

Compound 3, half-maximal inhibitory concentration: 2.36 ug/mL
Compound 3: middle estimate off by 2.5-fold (0.41 log units), on the high side; measured number below the stated range.
By their numbers in this assay, from the lowest: compound 3; then compounds 2 and 1 (each within the scatter of the next).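

In this assay, for the compounds shown here, the group on the saturated ring carbon now shows a real effect on the number: 2-chlorophenyl in place of 4-bromophenyl gives the first step beyond the scatter (a 2.1-fold lower number from compound 2 to compound 3 (0.33 log units; beyond the scatter)). Against 4-methoxyphenyl, the same 2-chlorophenyl gives a step that is also beyond the scatter (a 3.1-fold lower number from compound 1 to compound 3 (0.49 log units; beyond the scatter)), although compound 1 and compound 2 cannot be ranked against each other. No supporting measurement is available to explain these lower numbers.

Chlorine replaces bromine and the halogen's place on the phenyl ring changes in the same step, so 4-chlorophenyl and 2-bromophenyl would be needed to separate the two changes. Also open, as far as these compounds go, is how a phenyl ring carrying an amine or a carboxylic acid would compare.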